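The compounds below may be only part of what the source reports. "The series", "measured", "known", "first", "only" and "open" are said of these compounds alone.

Of the compounds shown here, three from this series have been tested in a functional assay on A-375 cells (Homo sapiens) for cytotoxicity, read by MTT assay, with a stated time of 72 h, tested at 10 uM; on this read-out higher numbers stand for more inhibition of growth at the one concentration tested and lower numbers for less inhibition of growth. Compound 1, with the structure `N/C(=N\NC(=S)N1CCSCC1)c1ccccn1`, gives 83.9%. Compound 3, with the structure `N/C(=N\NC(=S)N1CCCCCC1)c1ccccn1`, gives 86.5%. Compound 2, with the structure `N/C(=N\NC(=S)N1CCN(c2ccccn2)CC1)c1ccc(F)cn1`, gives 56.8%, which is the lowest of the three numbers: compound 1 sits closest, at a value higher by more than the usual scatter, and compound 3 sits furthest, also higher by more than the scatter. Compounds 1 and 3 differ from compound 2 in more than one place. No single change can be tied to this gap.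

Compound 4, with the structure `Cc1ccnc(/C(N)=N/NC(=S)N2CCN(c3ccccn3)CC2)c1`, has not been measured. It differs from compound 2 in one place: 4-methylpyridin-2-yl in place of 5-fluoropyridin-2-yl on a carbon with a double bond to nitrogen. Within the data shown here, no pair of measured compounds differs in only this way, so there is nothing to show how large such a swap moves the number in this assay . The closest guide is that compound 2 gives 56.8% with its 5-fluoropyridin-2-yl group, while the two compounds lacking a substituent on that ring, which also carry different amine parts, score higher. A small rise, or a change that stays within the scatter, is expected for the step from compound 2 to compound 4 in this assay , namely a number 3.2 percentage points higher from compound 2 to compound 4 (within the scatter). Compound 4 is therefore estimated to give about 60%, in a range from 40% to 80%.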

Compound 4, percent growth inhibition at one concentration: 76%
Compound 4: middle estimate off by 16 percentage points, on the low side, within the range that was stated.
By their numbers in this assay, from the lowest: compound 2; then compounds 4, 1 and 3 (each within the scatter of the next, the first and the last beyond it).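

Among these compounds, this is the first pair that differs in one place only, so it gives a direct reading of the group on a carbon with a double bond to nitrogen: in this assay, 4-methylpyridin-2-yl in place of 5-fluoropyridin-2-yl gives a number 19.2 percentage points higher from compound 2 to compound 4 (beyond the scatter). The number therefore responds to this group, even though the two groups have the same number of heavy atoms and the rest of the molecule stays unchanged. No measurement at hand bears on the reason for this step.

As far as these compounds go, it stays open whether adding the methyl or removing the fluorine matters more, a question that plain pyridin-2-yl on the amine part of compound 2 would help settle. Also open, from the compounds shown here alone, are how 4-methoxypyridin-2-yl would score at this place and whether the same swap moves the number similarly with the amine parts of compound 1 and compound 3.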